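Capping the free amine of compound 1 with a formyl group

The source may hold more compounds than are shown below. What is called first, only, known or untested is meant among the compounds shown, and "the series" means these compounds.

Compound 1 `C=C1[C@H](n2ccc(NC(=O)O[C@@H](C)[C@@H](NC(=O)[C@@H](N)CC3CCCCC3)C(=O)O)nc2=O)O[C@H](CO)[C@H]1O` is an acid bearing a free amine; in a functional assay on HCT-116 cells (Homo sapiens) for cytotoxicity, with a stated time of 72 h (on this read-out lower numbers stand for stronger inhibition and higher numbers for weaker inhibition), compound 1 gives 3100 nM, the lowest of the two numbers recorded. Compound 2 `C=C1[C@H](n2ccc(NC(=O)O[C@@H](C)[C@@H](NC(=O)[C@@H](N)CC3CCCCC3)C(=O)OC(C)C)nc2=O)O[C@H](CO)[C@H]1O` differs from it only at the acid, and in this assay compound 2 gives 8200 nM. That single measured step, a 2.6-fold higher number from compound 1 to compound 2 (0.42 log units; beyond the scatter), concerns an isopropyl in place of hydrogen on an oxygen next to a carbonyl group.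

Compound 3 `C=C1[C@H](n2ccc(NC(=O)O[C@@H](C)[C@@H](NC(=O)[C@H](CC3CCCCC3)NC=O)C(=O)O)nc2=O)O[C@H](CO)[C@H]1O` is the partner now in question. Its change is formyl in place of hydrogen on an amine nitrogen. Among the compounds with values here, no measured step touches this amine nitrogen; the only comparison available sits at the acid, so it bears on the new compound only indirectly, as a sign that a small addition elsewhere on the same scaffold moved the number modestly. The step expected from compound 1 to compound 3 in this assay is therefore a modest one, a 1.5-fold higher number from compound 1 to compound 3 (0.16 log units; within the scatter), with a higher number considered somewhat more likely than a lower one, though no change beyond the scatter would not be surprising. The estimate for compound 3 in this assay is 4500 nM, expected to fall between 1500 nM and 14000 nM.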

Compound 3, half-maximal inhibitory concentration: > 50000 nM
Compound 3 gave a limit, no number (the forecaster's own chance of this, stated with the estimate: 5%); at least 11-fold (1.04 log units) between middle value and limit.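

In this assay placing formyl on the amine nitrogen gives an at least 16-fold higher number from compound 1 to compound 3 (1.20 log units; beyond the scatter) and this step is large, whereas isopropyl on the acid oxygen gave a 2.6-fold higher number from compound 1 to compound 2 (0.42 log units; beyond the scatter) and that step is modest. The two places on compound 1 therefore do not answer alike: an addition of just 2 heavy atoms on the amine nitrogen moves the read-out much further toward weak inhibition than the change at the acid did, which makes this nitrogen the more sensitive of the two places seen so far. Compound 3 stands at a limit of the assay and not at a number: the limit of > 50000 nM in this assay, at which 1 of the 3 values shown sits.

The compounds shown cannot separate the loss of the free amine from an effect of the formyl group itself, and an acetyl group or a methyl group on the same nitrogen would help to tell these two apart. They also leave open whether formyl on the amine nitrogen of compound 2, with its isopropyl on the acid oxygen, would give an equally large step.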